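This account rests on a few compounds, and the source may have more. Where it says the series, first, only, none or still open, it means among the compounds named here.

Measured in an assay on brain (strain C57BL6) for displacement of a labelled ligand from AP2-associated protein kinase 1 (Mus musculus), read by scintillation counting, with a stated time of 1 h; a higher number here means a weaker inhibitor, a lower number a stronger inhibitor:

Compound 1 `CC(=O)Nc1cc(-c2ccc(OC[C@@H](N)CC(C)C)c(C)c2)ccn1`: 0.08 nM
Compound 2 `COC(=O)Nc1cc(-c2cc(C)c(OC[C@@](C)(N)CC(C)C)cn2)ccn1`: 1.4 nM
Compound 3 `COC(=O)Nc1cc(-c2ccc(OC[C@@](C)(N)CC(C)C)c(C)c2C)ccn1`: 0.26 nM

Among these three, compound 1 gives the lowest number and is the strongest inhibitor of the set. Compound 3 comes nearest to it, and its number is higher by a margin that lies beyond the scatter. Compound 2 is furthest away, with a number well above that of compound 1, again beyond the scatter. Compound 2 and compound 3 each differ from compound 1 in more than one place, so neither of them isolates a single structural change.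

The next compound, compound 4 `CC(=O)Nc1cc(-c2ccc(OC[C@@H](N)CC(C)C)cc2)ccn1`, differs from compound 1 in one place only: hydrogen in place of methyl on an aromatic carbon. Within the data shown here, no pair of measured compounds shows this exact change on its own, so no measured step can be carried over directly. On the compounds shown, the loss of that methyl is expected to cost some potency, a step of modest size toward a higher number, though an outcome within the scatter cannot be ruled out. Compound 4 is therefore expected to give about 0.3 nM in this assay, in a range from 0.08 nM to 1.2 nM, which means an expected step of a 3.8-fold higher number from compound 1 to compound 4 (0.57 log units; beyond the scatter).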

Compound 4, inhibition constant: 0.9 nM
Beside the measured number, compound 4's estimate is 3.0-fold (0.48 log units) below it; low and high end bracket the measured number.
By their numbers in this assay, from the lowest: compound 1; then compound 3; then compounds 4 and 2 (each within the scatter of the next).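

In this assay, among these compounds, the replacement of methyl by hydrogen gives an 11-fold higher number from compound 1 to compound 4 (1.05 log units; beyond the scatter) and this large step is the only change in the set that can be read on its own. It shows that the methyl on this aromatic carbon, ortho to the (2-amino-4-methylpentyl)oxy group, contributes substantially to the potency of compound 1, although the change removes only one heavy atom and alters no count of hydrogen-bond donors or acceptors and no net charge. Nothing available explains why so small a change in this position has so large an effect.

With only methyl and hydrogen compared on this carbon, the compounds shown leave open whether an ethyl group, a chlorine atom or a methoxy group there would match compound 1, fall short of it or improve on it. They also leave open whether losing this methyl would cost as much with a methyl carbamate in place of the acetamide, the group carried by compound 2 and compound 3.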